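This account rests on a few compounds, and the source may have more. Where it says the series, first, only, none or still open, it means among the compounds named here.

Compound 1 `COc1cc(/C=C/C(=O)/C=C/c2cc(OC)c(OC)c(OC)c2)ccc1OCc1cn(CCOc2cc(=O)oc3ccccc23)nn1` gives 820 nM in a functional assay on THP-1 cells (Homo sapiens) for cytotoxicity, read by sulforhodamine B assay, with a stated time of 48 h (on this read-out higher numbers stand for weaker inhibition and lower numbers for stronger inhibition), the lowest of the three numbers recorded; compound 3 `COc1ccc(/C=C/C(=O)/C=C/c2ccc(OCc3cn(CCOc4cc(=O)oc5ccccc45)nn3)c(OC)c2)cc1` gives 7410 nM and compound 2 `COc1cc(/C=C/C(=O)/C=C/c2cccc3ccccc23)ccc1OCc1cn(CCCOc2cc(=O)oc3ccccc23)nn1` gives 8410 nM. Compound 4 `COc1cc(/C=C/C(=O)/C=C/c2ccco2)ccc1OCc1cn(CCOc2cc(=O)oc3ccccc23)nn1` differs from compound 1 in one place: furan-2-yl in place of 3,4,5-trimethoxyphenyl on a double-bonded chain carbon bound to a double-bonded chain carbon. Going by the values given here, the only measured step that bears on this change is a 9.0-fold higher number from compound 1 to compound 3 (0.96 log units; beyond the scatter), where a smaller aryl group likewise took the place of 3,4,5-trimethoxyphenyl on a double-bonded chain carbon bound to a double-bonded chain carbon. A step of similar size and direction is therefore expected for compound 4, namely a 7.3-fold higher number from compound 1 to compound 4 (0.86 log units; beyond the scatter) in this assay. Compound 4 is estimated to give 6000 nM, with a range from 2000 nM to 20000 nM.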

Compound 4, half-maximal inhibitory concentration: 7870 nM
Beside the measured number, compound 4's estimate is 1.3-fold (0.12 log units) below it, within the range that was stated.
By their numbers in this assay, from the lowest: compound 1; then compounds 3, 4 and 2 (each within the scatter of the next).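

In this assay, furan-2-yl in place of 3,4,5-trimethoxyphenyl gives a 9.6-fold higher number from compound 1 to compound 4 (0.98 log units; beyond the scatter), so a second, quite different group on a double-bonded chain carbon also fails to keep the low number of compound 1. The step of a 1.1-fold higher number from compound 3 to compound 4 (0.03 log units; within the scatter) shows no separation between furan-2-yl and 4-methoxyphenyl, although one ring is five-membered and the other six-membered. No measurement at hand explains this result. From the compounds shown here alone, it remains open whether a 3,4-dimethoxyphenyl or 3,5-dimethoxyphenyl group would keep the low number of compound 1. Going by these compounds, the effect of a ring carrying an amine in this place also remains open.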